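The compounds below may be only part of what the source reports. "The series", "measured", "known", "first", "only" and "open" are said of these compounds alone.

Measured compounds:
compound 1, `O=C(CSc1nc(Nc2ccccc2)c2ccccc2n1)Nc1cccc(Cl)c1`: 14300 nM
compound 2, `O=C(CSc1nc(Nc2ccccc2)c2ccccc2n1)Nc1ccc(Br)cc1`: 19300 nM

In a functional assay on MGC-803 cells (Homo sapiens) for inhibition, read by MTT assay, with a stated time of 72 h (on this read-out higher numbers stand for weaker inhibition and lower numbers for stronger inhibition), compound 1 and compound 2 sit within the scatter of one another: a 1.3-fold higher number from compound 1 to compound 2 (0.13 log units; within the scatter). Compound 3, `O=C(CSc1nc(Nc2ccccc2)c2ccccc2n1)Nc1ccc(Cl)cc1Cl`, is not yet measured; it differs from compound 1 by 2,4-dichlorophenyl in place of 3-chlorophenyl on an amide-type nitrogen. Among the measured compounds shown here, the only measured step, a 1.3-fold higher number from compound 1 to compound 2 (0.13 log units; within the scatter), also exchanged one halogenated phenyl on that amide-type nitrogen for another and stayed within the scatter, so a step of about the same size is expected here: no change at the digits printed from compound 1 to compound 3 (within the scatter), with no change beyond the scatter. Compound 3 is therefore estimated at 14300 nM, between 6000 nM and 35000 nM.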

Compound 3, half-maximal inhibitory concentration: 12300 nM
Compound 3: middle estimate off by 1.2-fold (0.07 log units), on the high side; the range from low to high includes it.
By their numbers in this assay, from the lowest: compounds 3, 1 and 2 (each within the scatter of the next).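

In this assay, 2,4-dichlorophenyl in place of 3-chlorophenyl gives a 1.2-fold lower number from compound 1 to compound 3 (0.07 log units; within the scatter) and in place of 4-bromophenyl gives a 1.6-fold lower number from compound 2 to compound 3 (0.20 log units; within the scatter). The amide-type nitrogen therefore carries three different halogenated phenyls, including one with two chlorines, with all three compounds within the scatter of one another. Nothing available explains this result. From the compounds shown here alone, what a methoxy group, an amine or a carboxylic acid on that phenyl would do stays open, as does whether any change at this position can move the number beyond the scatter.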